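A new aryl group on the ring nitrogen of compound 1

The source may report more compounds than this note shows. Statements on the series, on what has been measured and on what is new or still open speak of the compounds shown alone.

Compound 1 `COc1cc2c(Oc3ccc(NC(=O)c4nn(-c5ccccc5C)c(=O)cc4C)cc3F)ccnc2cc1OCCCN1CCCCC1` gives 2810 nM in a functional assay on HT-29 cells (Homo sapiens) for inhibition, read by MTT assay, with a stated time of 72 h; on this read-out higher numbers stand for weaker inhibition and lower numbers for stronger inhibition.
Compound 2 `COc1cc2c(Oc3ccc(NC(=O)c4nn(-c5ccccc5C)c(=O)cc4C)cc3F)ccnc2cc1OCCCN1CCC(C)CC1` gives 2810 nM in this assay.
Compound 3 `COc1cc2c(Oc3ccc(NC(=O)c4nn(-c5ccccc5C)c(=O)cc4C)cc3F)ccnc2cc1OCCCN1CCN(C)CC1` gives 3790 nM in this assay.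

Compound 1 stands level with compound 2 at the digits shown, and together they hold the lowest numbers of the three; compound 3 sits only slightly apart. All the steps among these three lie within the scatter: no change at the digits printed from compound 1 to compound 2 (within the scatter), a 1.3-fold higher number from compound 1 to compound 3 (0.13 log units; within the scatter), and a 1.3-fold higher number from compound 2 to compound 3 (0.13 log units; within the scatter). Each of them alters only the saturated amine at the end of the chain.

Compound 4 `COc1ccc(-n2nc(C(=O)Nc3ccc(Oc4ccnc5cc(OCCCN6CCCCC6)c(OC)cc45)c(F)c3)c(C)cc2=O)cc1` is changed elsewhere: 4-methoxyphenyl in place of 2-methylphenyl on an aromatic nitrogen. Among the compounds with values here, none of the measured steps touches this part of the shared core, so none bears directly on it. What the measured steps do show is that changes at the chain end moved nothing beyond the scatter, but this gives no guide for a change on the aromatic nitrogen. With nothing to lean on, no step beyond the scatter is assumed, though the uncertainty is wide. Compound 4 is therefore expected to give about 2800 nM, within a range of 900 nM to 9000 nM, in this assay. This estimate corresponds to an expected step of a 1.0-fold lower number from compound 1 to compound 4 (0.00 log units; within the scatter).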

Compound 4, half-maximal inhibitory concentration: 3200 nM
Estimate against measurement, compound 4: 1.1-fold (0.06 log units) below, within the range that was stated.
By their numbers in this assay, from the lowest: compounds 1, 2, 4 and 3 (each within the scatter of the next).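

In this assay, putting 4-methoxyphenyl in place of 2-methylphenyl on the aromatic nitrogen gives a 1.1-fold higher number from compound 1 to compound 4 (0.06 log units; within the scatter) and so leaves the number within the scatter. Within the data shown here, the earlier compounds varied only the saturated amine at the end of the chain, so this is the first sign that the aryl group on this nitrogen can also be exchanged without a step beyond the scatter, even though the entering group brings one hydrogen-bond acceptor and the leaving group none. No measurement here offers an explanation for this result.

This single exchange removes a methyl and adds a methoxy together, so it cannot show whether each change alone does nothing or whether the two cancel. Also open, as far as these compounds go, is what a plain methyl in place of the whole aryl group, or an amine or a carboxylic acid on the phenyl ring, would do.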